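Acetyl to methyl on an aromatic carbon

The compounds below may be only part of what the source reports. "The series", "measured", "known", "first", "only" and "open" are said of these compounds alone.

In a functional assay on B16 cells (Mus musculus) for cytotoxicity, read by MTT assay, with a stated time of 48 h (on this read-out higher numbers stand for weaker inhibition and lower numbers for stronger inhibition), compound 1 (`CC1(C)CCCC2=CC=C(C=O)CC[C@]21C`) gives 145000 nM and compound 2 (`C#CC1=CC[C@]2(CC1)C(=C)CC[C@H]2C(C)C`) gives 123000 nM. Compound 3 (`C=C1CCC[C@]2(C)CCC(c3cn(-c4ccc(C(C)=O)cc4)nn3)=CC[C@@]12C`) gives 61000 nM. Among the measured compounds shown here, that number is lower than the one for compound 1, by a margin beyond the usual scatter, but it lies within the scatter of the one for compound 2. All three numbers sit in the same broad region of the scale.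

Compound 4 (`C=C1CCC[C@]2(C)CCC(c3cn(-c4ccc(C)cc4)nn3)=CC[C@@]12C`) keeps the shared core of compound 3 and carries methyl in place of acetyl on an aromatic carbon, para to a large group: methyl in place of acetyl on an aromatic carbon. The group sits on a six-membered aromatic ring of carbon only, and the rest of the structure is unchanged.

For the measured compounds named here, no pair of measured compounds differs in one place, so the data do not show what this exchange does in this assay. The expectation is therefore no step beyond the scatter, in either direction, with the number staying close to that of compound 3 at 61000 nM. The expected change is a 1.1-fold higher number from compound 3 to compound 4 (0.06 log units; within the scatter). For compound 4 the estimated value is 70000 nM, with an expected range from 35000 nM to 130000 nM.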

Compound 4, half-maximal inhibitory concentration: 57600 nM
Compound 4: the middle estimate sits 1.2-fold (0.08 log units) above what was measured, and the stated range covers the measured number.
By their numbers in this assay, from the lowest: compounds 4, 3, 2 and 1 (each within the scatter of the next, the first and the last beyond it).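

Among the compounds shown here, the exchange of acetyl for methyl on an aromatic carbon, para to a large group, gives the first comparison in this set between compounds that differ in one place: in this assay the result is a 1.1-fold lower number from compound 3 to compound 4 (0.02 log units; within the scatter). Here, with the shared core unchanged, a group carrying a carbonyl and one hydrogen-bond acceptor gives way to one with neither, and the two compounds remain within the scatter of each other, which the earlier compounds, differing in more than one place, could not show. Nothing measured here bears on why these two compounds read alike.

What the compounds shown leave open is whether any group at this aromatic carbon would leave the number within the scatter, since an amine, a carboxylic acid or a longer chain such as butyl could behave differently from both acetyl and methyl. They also leave open whether the same exchange would give a similar result on a different core, as this is a single pair in a single assay.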